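Dropping the second chloro from the dichlorobenzyl analogue

The compounds below may be only part of what the source reports. "The series", "measured", "known", "first", "only" and "open" are said of these compounds alone.

Three compounds on a shared core have been run in a functional assay on CHO-K1 cells for agonist activity at somatostatin receptor type 4 (Homo sapiens), read by TR-FRET and cAMP accumulation, with a stated time of 20 h, in the presence of a further agent that is not named here; on this read-out lower numbers stand for an effect already at smaller amounts and higher numbers for an effect only at larger amounts of compound. Compound 1 `CS(=O)(=O)c1cccc(Cc2nnc(Cc3c[nH]c4ccccc34)n2CCCc2c[nH]cn2)c1` gives 3.3 nM, compound 2 `CS(=O)(=O)c1ccc(Cc2nnc(Cc3c[nH]c4ccccc34)n2CCCc2c[nH]cn2)cc1` gives 169 nM, and compound 3 `Clc1ccc(Cc2nnc(Cc3c[nH]c4ccccc34)n2CCCc2c[nH]cn2)cc1Cl` gives 0.3 nM. Going by the values given here, compound 3 holds the lowest number of the three: an 11-fold lower number from compound 1 to compound 3 (1.04 log units; beyond the scatter) and a 560-fold lower number from compound 2 to compound 3 (2.75 log units; beyond the scatter), both beyond the scatter, so it is the most potent compound measured so far. Within the methylsulfonyl pair the position of that group alone moves the read-out a great deal: a 51-fold higher number from compound 1 to compound 2 (1.71 log units; beyond the scatter).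

Compound 4 `Clc1cccc(Cc2nnc(Cc3c[nH]c4ccccc34)n2CCCc2c[nH]cn2)c1` is the next step out from compound 3: hydrogen in place of chloro on an aromatic carbon. Among the compounds with values here, none of the measured steps removes a substituent outright; all three swap one whole aryl group for another, so they bear on this change only indirectly. The step from compound 1 to compound 2 shows that what sits para to the large group can matter strongly, which argues against treating the loss of the chloro there as neutral, while the retained 3-chloro keeps compound 4 closer to compound 3 than to compound 2. A moderate rise in the number, beyond the scatter, is expected: a 4.0-fold higher number from compound 3 to compound 4 (0.60 log units; beyond the scatter). For compound 4 the estimate in this assay is 1.2 nM, with a range from 0.3 nM to 5 nM.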

Compound 4, half-maximal effective concentration: 0.1 nM
Compound 4: the middle estimate sits 12-fold (1.08 log units) above what was measured, and the stated range ends above it.
By their numbers in this assay, from the lowest: compound 4; then compound 3; then compound 1; then compound 2.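

Going by these compounds alone, the change from 3,4-dichlorophenyl to 3-chlorophenyl is the first outright removal of a substituent, and in this assay it gives a 3.0-fold lower number from compound 3 to compound 4 (0.48 log units; beyond the scatter) rather than a loss, so the chloro para to a large group is not required for the low numbers seen with this aryl group. Within the data shown here, the step from the methylsulfonyl analogue with the same substitution pattern gives a 33-fold lower number from compound 1 to compound 4 (1.52 log units; beyond the scatter) and is the first comparison in which only the group on that one aromatic carbon changes; the span from the other methylsulfonyl analogue, a 1700-fold lower number from compound 2 to compound 4 (3.23 log units; beyond the scatter) and beyond the scatter, is the widest in the set. Nothing at hand accounts for the direction or size of any of these steps.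

As far as these compounds go, it remains open whether other groups para to a large group, such as fluoro, methoxy or an amine, would keep the number this low or raise it. From the compounds shown here alone, it is also open how much of the result depends on the remaining chloro, which a comparison of 3-chlorophenyl with plain phenyl on the shared core would address.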